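Side-Chain Swap from Compound 2 to Compound 3

A few compounds are considered here, and "the series" means these few. Any claim that something is new, unique, unknown or untested is made for them only; others in the source may bear on it.

Compound 1 `O=C(O)C[C@@H](NC(=O)CC1OC(CO)C(O)C(O)C1O)C(=O)O` gives 6000000 nM in an assay on isolated protein for binding affinity to E-selectin (Homo sapiens); on this read-out higher numbers stand for weaker inhibition and lower numbers for stronger inhibition.
Compound 2 `NCCCC[C@@H](NC(=O)CC1OC(CO)C(O)C(O)C1O)C(=O)O` gives 7000000 nM in this assay.

Both compounds share the same core and differ only in the side chain attached to the amino-acid part. The step of a 1.2-fold higher number from compound 1 to compound 2 (0.07 log units; within the scatter) shows that exchanging one side chain for another left the read-out essentially unchanged. Compound 2 carries the higher of the two numbers, but its gap to compound 1 lies within the scatter, so the two cannot be ranked against each other.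

Compound 3 `NC(=O)CC[C@@H](NC(=O)CC1OC(CO)C(O)C(O)C1O)C(=O)O` has not yet been measured. It differs from compound 2 by carbamoyl in place of 2-aminoethyl on a saturated chain carbon, three bonds along the chain from an amide-type nitrogen and a carbonyl carbon. Going by the values given here, the only measured step that bears on this is a 1.2-fold higher number from compound 1 to compound 2 (0.07 log units; within the scatter), where a different side chain was exchanged on the same kind of chain carbon and the read-out did not move beyond the scatter. Given that this assay has so far been indifferent to the side chain, the step expected here, a 1.1-fold lower number from compound 2 to compound 3 (0.03 log units; within the scatter), is one that stays within the scatter. Compound 3 is therefore estimated at 6500000 nM, with a range from 3000000 nM to 14000000 nM.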

Compound 3, half-maximal inhibitory concentration: > 10000000 nM
Compound 3 ended at the assay's limit; the forecaster's own chance of this, stated with the estimate: 20%; middle value at least 1.5-fold (0.18 log units) from the limit.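

The new result adds a third kind of side chain at this position, and carbamoyl, with the 2-carbamoylethyl chain it forms, brings no stronger inhibition than the side chains of compound 1 and compound 2. In this assay compound 3 gives > 10000000 nM, which is a limit of the assay and not a number. Only lower bounds can be stated, namely an at least 1.4-fold higher number from compound 2 to compound 3 (0.15 log units; that floor lies within the scatter) and an at least 1.6-fold higher number from compound 1 to compound 3 (0.22 log units; that floor lies within the scatter), and the true size of the change stays unknown because the reading stops at the limit: the limit of > 10000000 nM in this assay, at which 1 of the 3 values shown sits.

Since both floors lie within the scatter, these values do not establish that compound 3 is truly weaker than compound 1 or compound 2, and whether this position affects the read-out at all remains unresolved. Also open is whether a carboxylic acid in place of carbamoyl on the same 2-carbamoylethyl chain, or a phenyl group on this saturated chain carbon, would give a value clearly lower than those of the three compounds shown.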